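Amide Side Chain Homologue Awaits Testing in Mice

The compounds below may be only part of what the source reports. "The series", "measured", "known", "first", "only" and "open" are said of these compounds alone.

Three compounds built on one shared core have been examined in a functional assay on the whole organism (Tail, strain ICR) with Mus musculus as the target, in the tail flick test, with a stated time of 120 min, at a dose of 25 umol/kg by the oral route; on this read-out higher numbers stand for a stronger effect at the one dose given and lower numbers for a weaker effect. Compound 1 `O=C(CN(c1nc(Cl)nc2[nH]cnc12)C1CC1)N[C@@H](CO)C(=O)O` gives 39%. Compound 2 `NC(=O)C[C@H](NC(=O)CN(c1nc(Cl)nc2[nH]cnc12)C1CC1)C(=O)O` gives 17%, and compound 3 `O=C(O)C[C@H](NC(=O)CN(c1nc(Cl)nc2[nH]cnc12)C1CC1)C(=O)O` gives 22%. Among these three numbers compound 3 stands second highest: its nearest neighbour is compound 2, whose value lies within the usual scatter of repeated runs, while compound 1 lies beyond it. Accordingly the change a number 5 percentage points higher from compound 2 to compound 3 (within the scatter), hydroxy in place of amino on a carbonyl carbon, counts as no real change. Exchanging the hydroxy on the chain carbon did matter: a number 22 percentage points lower from compound 1 to compound 2 (beyond the scatter), and likewise a number 17 percentage points lower from compound 1 to compound 3 (beyond the scatter).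

Compound 4 `NC(=O)CC[C@H](NC(=O)CN(c1nc(Cl)nc2[nH]cnc12)C1CC1)C(=O)O` is the next candidate. It differs from compound 3 in one place: carbamoylmethyl in place of carboxy on a saturated chain carbon, two bonds along the chain from an amide-type nitrogen and a carbonyl carbon. This brings back the carbamoyl group of compound 2, set one carbon further along the chain. Going by the values given here, the only measured step that bears directly on an amide against an acid at this position is small, and because a number 5 percentage points higher from compound 2 to compound 3 (within the scatter) lay within the scatter, compound 4 is expected to show a number 2 percentage points lower from compound 3 to compound 4 (within the scatter). Compound 4 is therefore estimated at 20%, with a likely range from 8% to 34%.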

Compound 4, a percentage reported as activity, at one dose (the size of the read-out at that dose, not a potency): 17.8%
Compound 4: the middle estimate sits 2.2 percentage points above what was measured, and the stated range covers the measured number.
By their numbers in this assay, from the lowest: compounds 2, 4 and 3 (each within the scatter of the next); then compound 1.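

In this assay the result shows that moving the carbamoyl group one carbon further along the chain makes no readable difference, as the step of a number 0.8 percentage points higher from compound 2 to compound 4 (within the scatter) shows, and that carbamoylmethyl in place of carboxy also stays level, with a number 4.2 percentage points lower from compound 3 to compound 4 (within the scatter) as its step. Going by these compounds alone, the side chains of compound 2, compound 3 and compound 4 therefore form one cluster whatever their length or end group, while the hydroxy of compound 1 remains the only group at this position that stands apart, seen again in a number 21.2 percentage points lower from compound 1 to compound 4 (beyond the scatter) as the step to the new compound. Nothing in the available information explains why the hydroxy compound differs from the other three.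

Still open, from the compounds shown here alone, is whether the hydroxy itself is what matters, which a longer chain ending in hydroxy, such as 2-hydroxyethyl, or a plain methyl at the same place would help to separate. A basic side chain such as aminomethyl also lies outside these compounds, so its place among these numbers at this single dose and time remains unknown.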